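Widening the amine at the end of the chain

This account rests on a few compounds, and the source may have more. Where it says the series, first, only, none or still open, it means among the compounds named here.

Compound 1 `Cn1c(N)c(-c2nc3ccccc3[nH]2)c2nc(C#N)c(C#N)nc21`: > 50000 nM
Compound 2 `CCCCn1c(N)c(-c2nc3ccccc3[nH]2)c2nc(C#N)c(C#N)nc21`: > 50000 nM
Compound 3 `CN(C)CCCCn1c(-c2c(N)n(C)c3nc(C#N)c(C#N)nc23)nc2ccccc21`: 11300 nM

For the measured compounds named here, in a functional assay on K562 cells (Homo sapiens) for antiproliferative activity, read by MTT assay, with a stated time of 48 h (on this read-out lower numbers stand for stronger inhibition and higher numbers for weaker inhibition), compound 3 gives 11300 nM, the only true number of the three. Compound 1 stands at > 50000 nM, which is a limit of the assay and not a number. Compound 2 stands at the same kind of limit, > 50000 nM.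

Compound 4 `CCN(CC)CCCCn1c(-c2c(N)n(C)c3nc(C#N)c(C#N)nc23)nc2ccccc21` differs from compound 3 in one place: diethylamino in place of dimethylamino on a saturated chain carbon, four bonds along the chain from an aromatic nitrogen. In words, diethylamino stands in place of dimethylamino on a saturated chain carbon, four bonds along the chain from an aromatic nitrogen.

Going by the values given here, no measured step changes this amine directly. The nearest is an at least 4.4-fold lower number from compound 1 to compound 3 (0.64 log units; beyond the scatter), with 4-(dimethylamino)butyl in place of hydrogen on an aromatic nitrogen. The other is a step that the two limits leave unreadable from compound 1 to compound 2.

Compound 3 at 11300 nM is therefore the starting point, and no shift beyond the scatter is expected in this assay. The estimated step is a 1.1-fold lower number from compound 3 to compound 4 (0.05 log units; within the scatter). Compound 4 is expected near 10000 nM, with an estimated range of 4000 nM to 25000 nM.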

Compound 4, half-maximal inhibitory concentration: 3180 nM
Beside the measured number, compound 4's estimate is 3.1-fold (0.50 log units) above it; the whole stated range lies above it.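

In this assay, the amine at the end of the chain proves to be a place where a small change counts: diethylamino in place of dimethylamino gives a 3.6-fold lower number from compound 3 to compound 4 (0.55 log units; beyond the scatter), a step beyond the usual scatter. The earlier compounds shown here showed only that attaching the whole 4-(dimethylamino)butyl chain moved the number, whereas here the chain stays the same and only the groups on its amine differ, and the full 4-(diethylamino)butyl chain gives an at least 15-fold lower number from compound 1 to compound 4 (1.19 log units; beyond the scatter). That second step has no upper end, as its starting value is a limit and not a number: the limit of > 50000 nM in this assay, at which 2 of the 4 values shown sit.

The compounds shown leave open whether the trend carries on to dipropylamino or to a ring amine such as piperidine or morpholine. They also leave open how diethylamino behaves on a shorter chain, such as 3-(diethylamino)propyl, or on a longer chain.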